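Working notes: exchanging the side group of compound 1

The compounds below may be only part of what the source reports. "The series", "measured", "known", "first", "only" and "open" are said of these compounds alone.

Within the data shown here, in a functional assay on MGC-803 cells (Homo sapiens) for inhibition, read by CCK-8 assay, with a stated time of 48 h (on this read-out lower numbers stand for stronger inhibition and higher numbers for weaker inhibition), compound 1 `COc1ccc(CN(C(=O)CSc2nc3ccccc3o2)c2cc(OC)c(OC)c(OC)c2)cc1` gives 450 nM, the lowest number of the series so far. Compound 3 `COc1ccc(CN(C(=O)CSC(=S)N2CCc3ccccc3C2)c2cc(OC)c(OC)c(OC)c2)cc1` gives 5940 nM. Compound 2 `COc1ccc(CN(C(=O)CSC(=S)N2CCc3cc(Br)ccc32)c2cc(OC)c(OC)c(OC)c2)cc1` reads > 20000 nM, which is a limit of the assay.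

Compound 4 `CCN1CCN(CC(=O)N(Cc2ccc(OC)cc2)c2cc(OC)c(OC)c(OC)c2)CC1` is still unmeasured. It carries 4-ethylpiperazin-1-yl in place of (1,3-benzoxazol-2-yl)sulfanyl on a saturated chain carbon bound to a carbonyl carbon. Among the measured compounds shown here, no measured step covers this exact exchange, since the sulfur stays in compounds 2 and 3. The nearest evidence is the replacement of the group on that sulfur, which gave a 13-fold higher number from compound 1 to compound 3 (1.12 log units; beyond the scatter) and an at least 44-fold higher number from compound 1 to compound 2 (1.64 log units; beyond the scatter). Both steps are large and point to higher numbers, and none of the three compounds goes against this. A large step toward weaker inhibition in this assay is therefore expected, on the strength of a 13-fold higher number from compound 1 to compound 3 (1.12 log units; beyond the scatter) in particular. The expected change is an 8.9-fold higher number from compound 1 to compound 4 (0.95 log units; beyond the scatter). Compound 4 is estimated at 4000 nM, with an expected range of 800 nM to 20000 nM.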

Compound 4, half-maximal inhibitory concentration: > 20000 nM
Compound 4 gave a limit, no number; the forecaster's own chance of this, stated with the estimate: 15%; middle value at least 5.0-fold (0.69 log units) away from the limit.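

Replacing (1,3-benzoxazol-2-yl)sulfanyl with 4-ethylpiperazin-1-yl on a saturated chain carbon bound to a carbonyl carbon gives, in this assay, an at least 44-fold higher number from compound 1 to compound 4 (1.64 log units; beyond the scatter). Compound 4 reads > 20000 nM, which is a limit, and it shares that limit with compound 2: the limit of > 20000 nM in this assay, at which 2 of the 4 values shown sit. Among these compounds, compound 2 and compound 3 both keep the sulfur, whereas compound 4 loses both the sulfur and the aromatic rings of the side group, and it too falls short of compound 1, which among the four compounds remains the only one with a number below the limit and below that of compound 3.

The compounds shown do not separate the part played by the sulfur from that of the 1,3-benzoxazol-2-yl ring. An amine nitrogen in place of the sulfur, with the ring kept, would address this, as would a longer chain between the carbonyl and the sulfur.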